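Replacing the chain carboxy with a hydroxy group

The compounds below may be only part of what the source reports. "The series", "measured", "known", "first", "only" and "open" are said of these compounds alone.

Measured compounds and their values:
- Compound 1 `COC(=O)c1c(F)cccc1-c1ccc(CCc2ncc(CC(C)(C)C)n2CCC(=O)O)cc1` — 1 nM
- Compound 2 `COC(=O)c1c(F)cccc1-c1ccc(CCc2ncc(CC(C)(C)C)n2CCOc2cccc(O)c2)cc1` — 13 nM
- Compound 3 `CC(C)(C)Cc1cnc(CCc2ccc(-c3cccc(F)c3C(=O)O)cc2)n1CCC(=O)O` — 11 nM

In an assay on cells for agonist activity at Bombesin receptor subtype-3 (Homo sapiens), read by HTRF and inositol phosphate accumulation, with a stated time of 1 h (a higher number here means that more compound is needed for the effect, a lower number that less compound is needed), compound 3 gives 11 nM, the second highest of the three numbers. Its nearest neighbour is compound 2, which gives 13 nM, a gap that lies within the usual scatter. Compound 1 stands furthest away, and an 11-fold higher number from compound 1 to compound 3 (1.04 log units; beyond the scatter) is beyond the scatter.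

Compound 4 `CC(C)(C)Cc1cnc(CCc2ccc(-c3cccc(F)c3C(=O)O)cc2)n1CCO` has not yet been measured. It differs from compound 3 by hydroxy in place of carboxy on a saturated chain carbon, two bonds along the chain from an aromatic nitrogen. For the measured compounds named here, one measured step bears on this change: a 13-fold higher number from compound 1 to compound 2 (1.11 log units; beyond the scatter) also replaced the carboxy group on that chain carbon, there by 3-hydroxyphenoxy, and gave a large increase in the number. Since the carboxy group is removed again here, a step in the same direction is expected, a 9.1-fold higher number from compound 3 to compound 4 (0.96 log units; beyond the scatter), though a hydroxy group is not the same replacement, so the size is uncertain. The estimate for compound 4 in this assay is 100 nM, within a range from 25 nM to 400 nM.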

Compound 4, half-maximal effective concentration: 3 nM
Beside the measured number, compound 4's estimate is 33-fold (1.52 log units) above it, outside the stated range (below it).
By their numbers in this assay, from the lowest: compound 1; then compound 4; then compounds 3 and 2 (each within the scatter of the next).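

In this assay hydroxy in place of carboxy gives a 3.7-fold lower number from compound 3 to compound 4 (0.56 log units; beyond the scatter) and so the number falls rather than rises. The earlier replacement on this saturated chain carbon gave a 13-fold higher number from compound 1 to compound 2 (1.11 log units; beyond the scatter) with 3-hydroxyphenoxy entering, so losing the carboxy group does not by itself raise the number, and the direction of the step depends at least on what enters or on the rest of the compound. Nothing shown here gives a measured reason for the fall in compound 4.

Going by these compounds, whether hydroxy would give a step of the same direction and size with the methyl ester of compound 1 in place of the carboxy group on the fluorinated ring remains open. So does the outcome for an amine, a methoxy group or a longer chain ending in hydroxy at this position.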